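Urea aryl variation on the shared core

The source may hold more compounds than are shown below. What is called first, only, known or untested is meant among the compounds shown, and "the series" means these compounds.

For the measured compounds named here, compound 2 `CC(C)(C)c1ccc(NC(=O)Nc2cccc(CNc3ncnc4ccccc34)c2)cc1` stands lowest of the two numbers so far in a functional assay on MGC-803 cells (Homo sapiens) for antiproliferative activity, read by MTT assay (a higher number here means a weaker inhibitor, a lower number a stronger inhibitor), at 7470 nM. Going by the values given here, its only neighbour, compound 1 `COc1ccccc1NC(=O)Nc1cccc(CNc2ncnc3ccccc23)c1`, gives 39300 nM in this assay, and the single measured step, a 5.3-fold lower number from compound 1 to compound 2 (0.72 log units; beyond the scatter), is modest. Compound 3 `O=C(Nc1ccc(F)cc1)Nc1cccc(CNc2ncnc3ccccc23)c1` carries the change (fluoro in place of tert-butyl on an aromatic carbon). Among the compounds with values here, no measured step covers this swap, so the expectation is loose. Compound 3 is expected to move back toward compound 1, whose number was 39300 nM. The step expected for compound 3 is a 2.7-fold higher number from compound 2 to compound 3 (0.43 log units; beyond the scatter). Compound 3 is therefore estimated at 20000 nM in this assay, within 7000 nM to 55000 nM.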

Compound 3, half-maximal inhibitory concentration: 44300 nM
Compound 3: middle estimate off by 2.2-fold (0.35 log units), on the low side, and the stated range covers the measured number.
By their numbers in this assay, from the lowest: compound 2; then compounds 1 and 3 (each within the scatter of the next).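

Fluoro in place of tert-butyl on this aromatic carbon gives a 5.9-fold higher number from compound 2 to compound 3 (0.77 log units; beyond the scatter) and so undoes the gain seen with compound 2. For the compounds shown here, the 4-fluorophenyl and 2-methoxyphenyl groups cannot be separated, with a 1.1-fold higher number from compound 1 to compound 3 (0.05 log units; within the scatter) in this assay so far, leaving only the 4-(tert-butyl)phenyl group of compound 2 apart from the other two. Nothing available explains the difference between tert-butyl and fluoro here.

Open, on these data alone, is whether a smaller alkyl group such as methyl or isopropyl at this place would keep the number of compound 2. As far as these compounds go, how an amine or a carboxylic acid would read there also remains open.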